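The source may report more compounds than this note shows. Statements on the series, on what has been measured and on what is new or still open speak of the compounds shown alone.

Compound 1 `COc1ccc(NC(=O)C(=O)c2cn(C(C)C)c3ccccc23)cc1` gives 181 nM in a functional assay on FaDu cells (Homo sapiens) for cytotoxicity, read by MTT assay, with a stated time of 72 h; on this read-out lower numbers stand for higher toxicity in this test and higher numbers for lower toxicity in this test. Compound 2 `COc1ccc(NC(=O)C(=O)c2cn(C(C)C)c3ccccc23)cn1` gives 85 nM in this assay, a step of a 2.1-fold lower number from compound 1 to compound 2 (0.33 log units; beyond the scatter) that follows the change (6-methoxypyridin-3-yl in place of 4-methoxyphenyl on an amide-type nitrogen). Compound 3 `COc1ccc(NC(=O)C(=O)c2cn(C(C)C)c3ccc(Cl)cc23)cc1` gives > 10000 nM in this assay; this is the limit of > 10000 nM in this assay, at which 1 of the 3 values shown sits, so its value is a limit and not a number. The step from compound 1 to compound 3 is an at least 55-fold higher number from compound 1 to compound 3 (1.74 log units; beyond the scatter), brought about by chloro in place of hydrogen on an aromatic carbon.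

Among the measured compounds shown here, compound 4 `COc1ccc(NC(=O)C(=O)c2cn(C(C)C)c3cccc(Cl)c23)cn1` carries chloro in place of hydrogen on an aromatic carbon, the same kind of change as the one from compound 1 to compound 3, though not the same: there the chloro sits meta to a fused ring and para to a fused ring, here it sits ortho to a fused ring and meta to a fused ring. Resting on the step of an at least 55-fold higher number from compound 1 to compound 3 (1.74 log units; beyond the scatter) of compound 3, compound 4 is expected to show a large loss, estimated as a 47-fold higher number from compound 2 to compound 4 (1.67 log units; beyond the scatter). Compound 4 is thus estimated at 4000 nM in this assay, within 400 nM to 20000 nM.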

Compound 4, concentration lethal to 50% of the cells: 2130 nM
Compound 4: middle estimate off by 1.9-fold (0.27 log units), on the high side; measured number inside the range.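

The step of a 25-fold higher number from compound 2 to compound 4 (1.40 log units; beyond the scatter) in this assay follows chloro in place of hydrogen, so the change goes the same way on both cores, although here the chloro sits ortho to a fused ring and meta to a fused ring, not where it sits in compound 3. Set side by side, the two steps cannot be told apart in size: the same change on two cores in this assay, an at least 55-fold higher number (1.74 log units; beyond the scatter) from compound 1 to compound 3 and a 25-fold higher number (1.40 log units; beyond the scatter) from compound 2 to compound 4; the limit leaves it open whether they differ. Since the two pairs differ in the place of the chloro as well as in the core, they do not separate what the place contributes from what the core contributes.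

The compounds shown leave open how a fluoro, a methyl or an amine in place of the chloro would read in this assay. They also leave open whether a smaller number can be kept with any group on this ring.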